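The source may report more compounds than this note shows. Statements on the series, on what has been measured and on what is new or still open speak of the compounds shown alone.

Measured so far in a functional assay on MCF7 cells (Homo sapiens) for antiproliferative activity, read by MTT assay, with a stated time of 48 h; a lower number here means a stronger inhibitor, a higher number a weaker inhibitor:
- compound 1 `O=C(N[C@@H](CCCCCCSSc1ccccn1)C(=O)Nc1nc(-c2ccccc2)cs1)OCc1ccccc1`: 3200 nM
- compound 2 `O=C(N[C@@H](CCCCCCSSc1ccccn1)C(=O)OCc1cccc([N+](=O)[O-])c1)OCc1ccccc1`: 15200 nM

Compound 1, at 3200 nM, holds the lower of the two numbers in this assay and is the stronger inhibitor of this pair. Compound 3 `O=C(N[C@@H](CCCCCCSSc1ccccn1)C(=O)OCc1cccc2ccccc12)OCc1ccccc1` has not yet been measured. It differs from compound 1 on a carbonyl carbon, where (naphthalen-1-yl)methoxy stands in place of (4-phenyl-1,3-thiazol-2-yl)amino: (naphthalen-1-yl)methoxy in place of (4-phenyl-1,3-thiazol-2-yl)amino on a carbonyl carbon.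

Among the measured compounds shown here, only one measured step bears on this change. In that step, (3-nitrobenzyl)oxy replaced the same (4-phenyl-1,3-thiazol-2-yl)amino group, giving a 4.8-fold higher number from compound 1 to compound 2 (0.68 log units; beyond the scatter), a modest change beyond the scatter. Compound 3 loses the same group, so a move to a higher number in this assay is expected, of similar or somewhat smaller size. This expectation rests on a single step, and the data do not show how far the naphthalene rings would behave like the nitro-bearing ring of compound 2. The expected change is a 2.8-fold higher number from compound 1 to compound 3 (0.45 log units; beyond the scatter). For compound 3 the estimated value is 9000 nM, with an expected range from 3500 nM to 22000 nM.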

Compound 3, half-maximal inhibitory concentration: 15300 nM
Estimate against measurement, compound 3: 1.7-fold (0.23 log units) below, within the range that was stated.
By their numbers in this assay, from the lowest: compound 1; then compounds 2 and 3 (each within the scatter of the next).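

In this assay, a second replacement of the (4-phenyl-1,3-thiazol-2-yl)amino group on this carbonyl carbon gives a 4.8-fold higher number from compound 1 to compound 3 (0.68 log units; beyond the scatter) and so matches the earlier step, which now no longer stands alone. The two replacements cannot be told apart, as swapping 3-nitrophenyl for naphthalen-1-yl on the saturated chain carbon bound to an oxygen next to a carbonyl group gives a 1.0-fold higher number from compound 2 to compound 3 (0.00 log units; within the scatter) and stays within the scatter. In these three compounds, then, the gap lies between compound 1 and the two compounds carrying an arylmethoxy group, while the change of aryl group between compound 2 and compound 3 leaves no visible mark on the number. Nothing given here accounts for the gap seen at this position.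

From the compounds shown here alone, what remains open is which part of the departing group matters, since the amide hydrogen and the 4-phenyl-1,3-thiazol-2-yl ring leave together in both steps. A benzylamino group on the same carbonyl carbon would keep the amide hydrogen without that ring, and how such a compound would compare with compound 1 cannot be told from these compounds.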